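The source may report more compounds than this note shows. Statements on the series, on what has been measured and on what is new or still open speak of the compounds shown alone.

Compounds measured so far:

Compound 1 `CCCn1c(=O)[nH]c2nc(-c3ccc(S(=O)(=O)N4CCN(c5cccc(F)c5)CC4)cc3)[nH]c2c1=O` – in an assay on CHO cells for displacement of a labelled ligand from adenosine receptor A1 (Homo sapiens), read by scintillation counting, with a stated time of 90 min, in the presence of a further agent that is not named here (a higher number here means a weaker inhibitor, a lower number a stronger inhibitor), compound 1 gives only a limit, > 1000 nM.

Compound 2 `CCCn1c(=O)c2[nH]c(-c3ccc(S(=O)(=O)N4CCN(c5ccc(Cl)cc5)CC4)cc3)nc2n(C)c1=O` – in this assay compound 2 also gives only a limit, > 1000 nM.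

Compound 1 therefore sits where every value shown sits, at the limit of > 1000 nM in this assay, at which 2 of the 2 values shown sit. Going by the values given here, no step between measured compounds exists. Compound 3 `CCCn1c(=O)[nH]c2nc(-c3ccc(S(=O)(=O)N4CCN(c5ccccc5C)CC4)cc3)[nH]c2c1=O` differs from compound 1 in one place: 2-methylphenyl in place of 3-fluorophenyl on an amine nitrogen in a ring. With both measured values at the same limit, no shift beyond the usual scatter is expected for the step that the limit leaves unreadable from compound 1 to compound 3. Compound 3 is expected to give about 3000 nM, probably between 1000 nM and 20000 nM, most likely again only a limit.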

Compound 3, inhibition constant: 419 nM
For compound 3 the middle estimate is 7.2-fold (0.85 log units) above the measured one; the whole stated range lies above it.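

In this assay, the group on the amine nitrogen in the ring clearly matters: 2-methylphenyl in place of 3-fluorophenyl gives an at least 2.3-fold lower number from compound 1 to compound 3 (0.37 log units; beyond the scatter). Compound 3 is the first compound shown to give a number rather than a limit, so a change at this position alone can move the read-out. The true size of the step stays unknown, since compound 1 gives only a limit: the limit of > 1000 nM in this assay, at which 2 of the 3 values shown sit.

The step changes both the substituent and its place on the phenyl ring, so these two effects cannot be separated. Values for 3-methylphenyl, 2-fluorophenyl and unsubstituted phenyl would tell them apart.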